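Adding a third methoxy to the chalcone-side ring of compound 3

This account rests on a few compounds, and the source may have more. Where it says the series, first, only, none or still open, it means among the compounds named here.

The series is built from three measured pyrazole chalcones. Compound 1 `COc1ccc(-c2cc(/C=C/C(=O)c3cc(OC)c(OC)c(OC)c3)[nH]n2)cc1OC` gives -88% in a functional assay on COLO 205 cells (Homo sapiens) for cytotoxicity, read by sulforhodamine B assay, with a stated time of 48 h, tested at 100 uM (on this read-out higher numbers stand for a weaker effect at the one concentration tested and lower numbers for a stronger effect), compound 2 `COc1ccc(C(=O)/C=C/c2cc(-c3cc(OC)c(OC)c(OC)c3)n[nH]2)cc1` gives -81%, and compound 3 `COc1ccc(C(=O)/C=C/c2cc(-c3cc(OC)c(OC)c(OC)c3)n[nH]2)cc1OC` gives -75%. Against compound 1, compound 3 reads higher, a gap beyond the scatter; against compound 2 the gap is within the scatter, so no order between those two can be claimed. For the measured compounds named here, the one single-point step known, from compound 2 to compound 3, brought a number 6 percentage points higher from compound 2 to compound 3 (within the scatter) for a methoxy in place of hydrogen on an aromatic carbon.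

Compound 4 `COc1cc(C(=O)/C=C/c2cc(-c3cc(OC)c(OC)c(OC)c3)n[nH]2)cc(OC)c1OC` is not yet measured. It differs from compound 3 by methoxy in place of hydrogen on an aromatic carbon. The step from compound 2 to compound 3 is the only measured one that bears on this change, and it stayed within the scatter. A second methoxy of the same kind is therefore expected to move the number by a number 5 percentage points higher from compound 3 to compound 4 (within the scatter), with no step beyond the scatter foreseen. The estimate for compound 4 is -70%, within a range from -88% to -50%.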

Compound 4, a percentage reported as activity, at one concentration (the size of the read-out at that concentration, not a potency): -100%
Beside the measured number, compound 4's estimate is 30 percentage points above it; measured number below the stated range.
By their numbers in this assay, from the lowest: compound 4; then compounds 1, 2 and 3 (each within the scatter of the next, the first and the last beyond it).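

In this assay, methoxy in place of hydrogen on an aromatic carbon does not leave the number unchanged at this position, ortho to a methoxy group, meta to a large group and meta to a methoxy group: the change brought a number 25 percentage points lower from compound 3 to compound 4 (beyond the scatter). The only earlier step of this kind, a number 6 percentage points higher from compound 2 to compound 3 (within the scatter), gave no sign of such a shift, so it had not shown that a methoxy could matter on this ring. Compound 4 also separates from the other core, with a number 12 percentage points lower from compound 1 to compound 4 (beyond the scatter), and the same change therefore has no single size or direction across these compounds: the same change on two cores in this assay, a number 6 percentage points higher (within the scatter) from compound 2 to compound 3 and a number 12 percentage points lower (beyond the scatter) from compound 1 to compound 4, 18 percentage points apart, beyond the scatter of two such steps.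

The compounds shown leave open whether the shift belongs to the methoxy itself or would also appear with an ethoxy, a hydroxy or an amine on the same carbon. They also leave open how compound 4 ranks in potency, since each number is the size of the read-out at one concentration in one cell line, and two steps cannot show how far this dependence on the core extends.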